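Swapping the Amine on the Thiocarbonyl Carbon: Toward Compound 3

A few compounds are considered here, and "the series" means these few. Any claim that something is new, unique, unknown or untested is made for them only; others in the source may bear on it.

Compound 1 `O=c1cc(CSC(=S)N2CCCC2)oc2cc(Cl)ccc12` and compound 2 `CCN(CC)C(=S)SCc1cc(=O)c2ccc(Cl)cc2o1` share one core and differ only in the amine attached to the thiocarbonyl carbon. In a functional assay on LM7 cells (Homo sapiens) for antiproliferative activity, read by MTT assay, with a stated time of 72 h (on this read-out lower numbers stand for stronger inhibition and higher numbers for weaker inhibition), compound 1 returns > 25000 nM, which is a limit of the assay and not a number, sitting at the limit of > 25000 nM in this assay, at which 1 of the 2 values shown sits. In this assay compound 2 gives 8800 nM, the only number obtained so far among these compounds. The measured step reads an at least 2.8-fold lower number from compound 1 to compound 2 (0.45 log units; beyond the scatter). Compound 3 `O=c1cc(CSC(=S)N2CCOCC2)oc2cc(Cl)ccc12` is the next member: morpholin-4-yl in place of diethylamino on a thiocarbonyl carbon. Within the data shown here, the single measured step bears directly on this change, since it also exchanged the amine on the thiocarbonyl carbon, running from a cyclic amine to the open diethylamino with a gain that was at least modest. Compound 3 returns to a cyclic amine, morpholin-4-yl, so a step in the reverse direction, weakening and beyond the scatter, is expected in this assay. The expected step is a 2.5-fold higher number from compound 2 to compound 3 (0.40 log units; beyond the scatter). Compound 3 is therefore estimated at 22000 nM, within a range from 7000 nM to 70000 nM, with a real chance that only a limit is reported.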

Compound 3, half-maximal inhibitory concentration: > 25000 nM
Compound 3 gave a limit, no number; the forecaster's own chance of this, stated with the estimate: 40%; middle value at least 1.1-fold (0.05 log units) from the limit.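

In this assay, morpholin-4-yl in place of diethylamino on a thiocarbonyl carbon gives an at least 2.8-fold higher number from compound 2 to compound 3 (0.45 log units; beyond the scatter), so the loss seen earlier with pyrrolidin-1-yl is no longer tied to a single ring amine. Among the three amines shown, only diethylamino gives a number, while compound 1 and compound 3, each with a ring amine, both end at a limit of the assay and not at a number: the limit of > 25000 nM in this assay, at which 2 of the 3 values shown sit. The step between those two compounds cannot be read, so the added ring oxygen of morpholin-4-yl cannot be ranked against pyrrolidin-1-yl, and the hydrogen-bond acceptor it brings has no readable effect of its own.

As far as these compounds go, it remains open whether the activity of compound 2 belongs to open-chain amines in general or to diethylamino in particular, a question that dimethylamino or dipropylamino on the same thiocarbonyl carbon would address. From the compounds shown here alone, it is also open whether a different ring amine, such as piperidin-1-yl, would return a number in this assay and so allow ring amines to be compared with one another.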